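This account rests on a few compounds, and the source may have more. Where it says the series, first, only, none or still open, it means among the compounds named here.

- Compound 1 `N#Cc1cnc(NCc2cnccc2C(F)(F)F)cc1N[C@H]1CC[C@@H](O)CC1`: 33%
- Compound 2 `N#Cc1cnc(NCc2cnccc2C(F)(F)F)cc1N[C@H]1CC[C@@H](C(N)=O)CC1`: 90%

In an ADME assay on S9 fraction from liver (Homo sapiens) for metabolic stability, with a stated time of 1 h (on this read-out lower numbers stand for a less stable compound and higher numbers for a more stable compound), compound 2 holds the higher of the two measured numbers, at 90%. Compound 3 `CN(C)C(=O)[C@H]1CC[C@@H](Nc2cc(NCc3cnccc3C(F)(F)F)ncc2C#N)CC1` has not yet been measured. It has dimethylamino in place of amino on a carbonyl carbon. Among the measured compounds shown here, only one measured step bears on this change, and it bears only indirectly. Replacing hydroxy with carbamoyl on a saturated ring carbon gave a large rise, a number 57 percentage points higher from compound 1 to compound 2 (beyond the scatter). Compound 3 keeps the carbonyl gained in that step, so it is expected to stay closer to compound 2 than to compound 1. For the measured compounds named here, no measured pair tests dimethylamino against amino, so the size of the step remains uncertain. With compound 2 at 90%, there is little room for a rise, and a moderate fall is expected: a number 15 percentage points lower from compound 2 to compound 3 (beyond the scatter). For compound 3, the estimated value is 75%, with an expected range of 50% to 93%.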

Compound 3, percent of the compound remaining: 48%
Compound 3: the middle estimate sits 27 percentage points above what was measured, and the stated range ends above it.
By their numbers in this assay, from the lowest: compound 1; then compound 3; then compound 2.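

In this assay, the high number of compound 2 proves sensitive to what sits on the carbonyl carbon: dimethylamino in place of amino gives a number 42 percentage points lower from compound 2 to compound 3 (beyond the scatter) for this one change. Keeping the carbonyl is therefore not enough to hold most of the gain, as dimethylcarbamoyl in place of hydroxy on a saturated ring carbon gives only a number 15 percentage points higher from compound 1 to compound 3 (beyond the scatter) in the same read-out. No measurement here offers a reason for the fall.

The compounds shown do not separate the loss of the amide hydrogen from the addition of the two carbons. Methylamino on the same carbonyl carbon would help to tell these apart, while a carboxylic acid in place of the amide would show whether the carbonyl needs a nitrogen at all.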